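The source may report more compounds than this note shows. Statements on the series, on what has been measured and on what is new or still open speak of the compounds shown alone.

In a functional assay on MDA-MB-231 cells (Homo sapiens) for inhibition, read by MTT assay, with a stated time of 48 h (a higher number here means a weaker inhibitor, a lower number a stronger inhibitor), three compounds have been measured that share one core and differ only in the group on a double-bonded chain carbon bound to a double-bonded chain carbon. Compound 1 `COc1cc(/C=C/c2ccc(NC(=O)/C=C/c3ccc(OC)c(OC)c3)cc2)cc(OC)c1` gives 7740 nM and compound 2 `COc1cc(/C=C/c2ccc(NC(=O)/C=C/c3ccc(C#N)cc3)cc2)cc(OC)c1` gives 7740 nM while compound 3 `COc1cc(/C=C/c2ccc(NC(=O)/C=C/c3ccc([N+](=O)[O-])cc3)cc2)cc(OC)c1` gives 11700 nM as its result. Compound 3 thus stands level with the other two, inside the usual scatter of such measurements.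

Compound 4 `COc1cc(/C=C/c2ccc(NC(=O)/C=C/c3ccc(F)cc3F)cc2)cc(OC)c1` is still unmeasured. It carries 2,4-difluorophenyl in place of 4-nitrophenyl at that same place (2,4-difluorophenyl in place of 4-nitrophenyl on a double-bonded chain carbon bound to a double-bonded chain carbon). Among the measured compounds shown here, three measured steps bear on this change: no change at the digits printed from compound 1 to compound 2 (within the scatter) and a 1.5-fold higher number from compound 1 to compound 3 (0.18 log units; within the scatter) and also a 1.5-fold higher number from compound 2 to compound 3 (0.18 log units; within the scatter) with each one within the scatter. No group with fluorine has been measured there yet, so this evidence is indirect. A step beyond the scatter is not expected in this assay for this exchange. The expected step is a 1.3-fold lower number from compound 3 to compound 4 (0.11 log units; within the scatter) and stays within the scatter. Compound 4 is estimated at 9000 nM with an expected range of 4000 nM to 20000 nM in all.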

Compound 4, half-maximal inhibitory concentration: > 20000 nM
Compound 4 was reported as a limit (the forecaster's own chance of this, stated with the estimate: 5%); middle value at least 2.2-fold (0.34 log units) from the limit.
By their numbers in this assay, from the lowest: compounds 1, 2 and 3 (each within the scatter of the next). At a limit, above all of these: compound 4.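

In this assay, compound 4, with 2,4-difluorophenyl on a double-bonded chain carbon bound to a double-bonded chain carbon, is reported only as a limit: the limit of > 20000 nM in this assay, at which 1 of the 4 values shown sits. Among the compounds shown here, this gives the first sign that the group at this place can matter, since the three earlier groups stayed within the scatter of one another, whereas the data show an at least 2.5-fold higher number from compound 2 to compound 4 (0.41 log units; beyond the scatter) and an at least 2.5-fold higher number from compound 1 to compound 4 (0.41 log units; beyond the scatter), both beyond the scatter. From the compounds shown here alone, the exchange for 4-nitrophenyl is less clear, with an at least 1.7-fold higher number from compound 3 to compound 4 (0.23 log units; that floor lies within the scatter), so that floor alone does not separate the two compounds, and the true size of all three steps remains unknown.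

The compounds shown leave open whether a single fluorine, as in 4-fluorophenyl, would behave like the 2,4-difluorophenyl group. They also do not show how a group carrying an amine or a carboxylic acid would read at this place.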